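The source may report more compounds than this note shows. Statements on the series, on what has been measured and on what is new or still open speak of the compounds shown alone.

Measured in a functional assay on ECa-109 cells (Homo sapiens) for inhibition, read by MTT assay, with a stated time of 72 h; on this read-out lower numbers stand for stronger inhibition and higher numbers for weaker inhibition:
- compound 1 `O=C(OCc1ccccc1)N1CCN(C(=S)SCc2cn(Cc3ccc(Cl)cc3)nn2)CC1`: > 128000 nM, a limit of the assay and not a number
- compound 2 `COc1ccc(Cn2cc(CSC(=S)N3CCN(C(=O)OCc4ccccc4)CC3)nn2)cc1`: 58300 nM
- compound 3 `Cc1ccc(Cn2cc(CSC(=S)N3CCN(C(=O)OC(C)(C)C)CC3)nn2)cc1`: 47900 nM

Compound 2 holds the highest of the two numbers; its nearest neighbour, compound 3, gives a value within the scatter of it, so no order between the two is read. The third value, that of compound 1, is only a limit.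

Compound 4 `O=C(OCc1ccccc1)N1CCN(C(=S)SCc2cn(Cc3ccc(F)cc3)nn2)CC1` differs from compound 2 by fluoro in place of methoxy on an aromatic carbon. Among the measured compounds shown here, one measured step bears on this change: an at least 2.1-fold lower number from compound 1 to compound 2 (0.34 log units; beyond the scatter). Compound 4 moves away from the methoxy group that went with that lower number and back to a halogen on the same aromatic carbon, so a higher number than that of compound 2 is expected, with a fair chance that this assay again reports only a limit, since compound 1 sits at the limit of > 128000 nM in this assay, at which 1 of the 3 values shown sits. For compound 4 the expected step is a 1.7-fold higher number from compound 2 to compound 4 (0.23 log units; within the scatter). Compound 4 is estimated at 100000 nM, within 45000 nM to 250000 nM.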

Compound 4, half-maximal inhibitory concentration: 32000 nM
Compound 4: middle estimate off by 3.1-fold (0.49 log units), on the high side; the whole stated range lies above it.
By their numbers in this assay, from the lowest: compounds 4, 3 and 2 (each within the scatter of the next). At a limit, above all of these: compound 1.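

On this aromatic carbon, para to a large group, the identity of the halogen matters: this assay shows an at least 4.0-fold lower number from compound 1 to compound 4 (0.60 log units; beyond the scatter). Fluoro and methoxy, by contrast, are not separated here, with a 1.8-fold lower number from compound 2 to compound 4 (0.26 log units; within the scatter), so no order between them is read and the earlier gain seen with methoxy is not specific to that group. Compound 1 stands only as a limit of the assay and not as a number: the limit of > 128000 nM in this assay, at which 1 of the 4 values shown sits.

The compounds shown do not tell how an amine or a carboxylic acid on this same carbon would read in this assay, nor how the unsubstituted phenyl would compare. Going by these compounds, it also remains open whether the gap between fluoro and chloro would persist with a tert-butyl carbamate in place of the benzyl carbamate.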